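Acetamido for methoxy on the aryl ether of compound 3

The compounds below may be only part of what the source reports. "The series", "measured", "known", "first", "only" and "open" are said of these compounds alone.

Compound 1, `Cc1cc(COc2ccccc2Cl)nc(-c2ccccn2)n1`: 316 nM
Compound 2, `Cc1cc(COc2ccc(Cl)cc2)nc(-c2ccccn2)n1`: 251 nM
Compound 3, `COc1ccc(OCc2cc(C)nc(-c3ccccn3)n2)cc1`: 7940 nM

In a functional assay on cells for antagonist activity at Free fatty acid receptor 1 (Homo sapiens), read by TR-FRET and inositol phosphate accumulation, with a stated time of 2 h (on this read-out lower numbers stand for stronger inhibition and higher numbers for weaker inhibition), compound 3 gives the highest of the three numbers, set apart from both others by steps beyond the scatter. Compound 4, `CC(=O)Nc1ccc(OCc2cc(C)nc(-c3ccccn3)n2)cc1`, differs from it by acetamido in place of methoxy on an aromatic carbon. Going by the values given here, no measured step exchanges methoxy for acetamido. Among the compounds with values here, the one step at this aromatic carbon, a 32-fold higher number from compound 2 to compound 3 (1.50 log units; beyond the scatter), was large, whereas a 1.3-fold lower number from compound 1 to compound 2 (0.10 log units; within the scatter) lay within the scatter. Within the data shown here, with no direct precedent, compound 4 is expected to stay close to compound 3, a step of a 1.0-fold higher number from compound 3 to compound 4 (0.00 log units; within the scatter) in this assay. Compound 4 is therefore estimated at 8000 nM in this assay, with a range from 2000 nM to 32000 nM.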

Compound 4, half-maximal inhibitory concentration: > 39800 nM
Compound 4 ended at the assay's limit; the forecaster's own chance of this, stated with the estimate: 25%; at least 4.9-fold (0.69 log units) between middle value and limit.
By their numbers in this assay, from the lowest: compounds 2 and 1 (each within the scatter of the next); then compound 3. At a limit, above all of these: compound 4.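

In this assay compound 4 stands at a limit of the assay and not at a number: the limit of > 39800 nM in this assay, at which 1 of the 4 values shown sits.

At this aromatic carbon, para to a large group, acetamido in place of methoxy gives an at least 5.0-fold higher number from compound 3 to compound 4 (0.70 log units; beyond the scatter), so a second group here moves the number upward from the value of compound 3. Acetamido in place of chloro gives an at least 150-fold higher number from compound 2 to compound 4 (2.20 log units; beyond the scatter), which leaves chloro with the lowest number of the three groups shown at this carbon.

The compounds shown leave open how a methyl group, a bromo group or a plain amine at this carbon would compare with chloro. From the compounds shown here alone, the full size of the step to compound 4 also stays open.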